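The source may hold more compounds than are shown below. What is called first, only, known or untested is meant among the compounds shown, and "the series" means these compounds.

In a functional assay on HL-60 cells (Homo sapiens) for cytotoxicity, read by luminescence and CellTiter-Glo, with a stated time of 3 days (a lower number here means a stronger inhibitor, a higher number a weaker inhibitor), three compounds built on one shared core have been measured. Compound 1 `O=C(Nc1ccc(C(F)(F)F)cc1)c1ccc(Cl)cc1O` gives 630 nM, and compound 3 `O=C(Nc1ccc(C(F)(F)F)cc1)c1ccc(F)cc1O` gives 680 nM; the step of a 1.1-fold higher number from compound 1 to compound 3 (0.03 log units; within the scatter) shows that swapping one halogen for another at that position left the numbers close together. Compound 2 `N#Cc1ccc(NC(=O)c2cc(Cc3ccccc3)ccc2O)cc1` gives 1740 nM, the highest of the three numbers, and it stands beyond the scatter from both compound 1 and compound 3.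

Compound 4 `N#Cc1ccc(NC(=O)c2cc(F)ccc2O)cc1` has not yet been measured. It differs from compound 2 in one place: fluoro in place of benzyl on an aromatic carbon. Among the measured compounds shown here, no measured step follows this same change, so the expectation rests on indirect evidence. Compound 4 carries the same fluoro group as compound 3, whose number lies well below that of compound 2; yet compound 4 also carries a nitrile where compound 3 carries trifluoromethyl, and nothing measured here isolates that exchange. A modest step is therefore expected, a 1.6-fold lower number from compound 2 to compound 4 (0.20 log units; within the scatter), most likely toward a lower number. For compound 4 the estimated value is 1100 nM, within a range from 400 nM to 3500 nM.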

Compound 4, half-maximal inhibitory concentration: 1420 nM
For compound 4 the middle estimate is 1.3-fold (0.11 log units) below the measured one; the measured number falls inside the stated range.
By their numbers in this assay, from the lowest: compounds 1 and 3 (each within the scatter of the next); then compounds 4 and 2 (each within the scatter of the next).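

In this assay, putting fluoro in place of benzyl, on the aromatic carbon para to a hydroxy group, gives a 1.2-fold lower number from compound 2 to compound 4 (0.09 log units; within the scatter). The earlier step exchanged one halogen for another, whereas this one removes a whole benzyl group with its aromatic ring and leaves a single fluorine atom, and even so the assay does not separate the two compounds. No measurement shown here explains this result.

As far as these compounds go, whether a charged group such as an amine or a carboxylic acid, or a longer chain, would fit this same pattern at this position remains open. Both compounds in this step also carry the nitrile, so the same exchange with trifluoromethyl in its place is an open question too.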